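A few compounds are considered here, and "the series" means these few. Any claim that something is new, unique, unknown or untested is made for them only; others in the source may bear on it.

Of the compounds shown here, three with a shared core have been measured in an assay on membranes from HeLa cells for displacement of a labelled ligand from adenosine receptor A3 (Homo sapiens), read by scintillation counting, with a stated time of 180 min, tested at 1 uM; a lower number here means less inhibition, a higher number more inhibition at the concentration tested (going by the name of the read-out). Among the measured compounds shown here, compound 1 `CCCOC(=O)C1=C(C)N(C)C(=O)NC1c1ccco1` gives 8%, and compound 2 `CCCOC(=O)C1=C(C)N(C)C(=O)NC1c1ccoc1` gives 16%; the step of a number 8 percentage points higher from compound 1 to compound 2 (within the scatter) is the only single-point change measured so far. Compound 3 `CCOC(=O)C1=C(C)N(C)C(=O)NC1c1cccs1` gives 2%, the lowest of the three numbers. Against compound 1 this is within the scatter, so the two cannot be ordered; against compound 2 the gap is beyond the scatter, so compound 3 does show less inhibition than compound 2.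

The step now followed leads to compound 4 `CCCOC(=O)C1=C(C)N(C)C(=O)NC1c1cccs1`, which differs from compound 3 by methyl in place of hydrogen on a saturated chain carbon, two bonds along the chain from an oxygen next to a carbonyl group. This change, ethoxy to propoxy, touches the ester chain and leaves the rest of the core untouched. For the measured compounds named here, no measured step bears directly on it: the one step known, from a furan-2-yl to a furan-3-yl group, concerns a different part of the molecule and was itself within the scatter. With nothing to suggest a move in either direction, and with all three numbers low, the expectation is a step of a number 3 percentage points higher from compound 3 to compound 4 (within the scatter) that stays within the scatter. Compound 4 is therefore estimated at 5%, with a likely range from -10% to 20%.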

Compound 4, a percentage reported as inhibition, at one concentration (the size of the read-out at that concentration, not a potency): 4%
Beside the measured number, compound 4's estimate is 1 percentage points above it, within the range that was stated.
By their numbers in this assay, from the lowest: compounds 3, 4, 1 and 2 (each within the scatter of the next, the first and the last beyond it).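

Adding a methyl to the ester chain, which turns ethoxy into propoxy, gives a number 2 percentage points higher from compound 3 to compound 4 (within the scatter) in this assay, so the first step read at this position shows no measurable effect on the number. Among the compounds shown here, with the propoxy chain held fixed, compound 4 also allows the ring group to be compared: thiophen-2-yl in place of furan-2-yl gives a number 4 percentage points lower from compound 1 to compound 4 (within the scatter) and leaves those two compounds unordered, whereas thiophen-2-yl in place of furan-3-yl gives a number 12 percentage points lower from compound 2 to compound 4 (beyond the scatter) and is the one new step that clears the scatter. That modest gap points to compound 2 showing more inhibition than compound 4, but nothing available explains this or either of the other two steps.

A single added methyl says little about the ester as a whole, so a longer chain such as butoxy, or a carboxylic acid in place of the ester, could behave differently. From the compounds shown here alone, with every number here low at one tested concentration, it also remains open whether any of these ring groups would matter on a compound showing much stronger inhibition.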